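Methoxy in Place of Hydrogen on the Shared Core

The source may hold more compounds than are shown below. What is called first, only, known or untested is meant among the compounds shown, and "the series" means these compounds.

Compound 2 `O=c1cc(-n2cc(COc3ccc(F)cc3)nn2)c2ccccc2o1` has the highest number among the three compounds measured in a functional assay on SW480 cells (Homo sapiens) for antiproliferative activity, read by MTT assay, with a stated time of 48 h (a lower number here means a stronger inhibitor, a higher number a weaker inhibitor), giving for compound 2 3820 nM. Compound 1 `O=c1cc(-n2cc(COc3ccc(F)cc3)nn2)c2cc(Br)ccc2o1` gives 1770 nM, and compound 3 `O=c1cc(-n2cc(COc3ccc(F)cc3)nn2)c2cc(O)ccc2o1` gives 2720 nM. Compound 4 `COc1ccc2c(-n3cc(COc4ccc(F)cc4)nn3)cc(=O)oc2c1` differs from compound 2 by methoxy in place of hydrogen on an aromatic carbon. Among the measured compounds shown here, two measured steps bear on this change at the same place: a 2.2-fold higher number from compound 1 to compound 2 (0.33 log units; beyond the scatter), and a 1.4-fold lower number from compound 2 to compound 3 (0.15 log units; within the scatter). Replacing the hydrogen there with a small group has so far given a lower number, once beyond the scatter and once within it. For compound 4 a small lowering is therefore expected, most likely within the scatter, as a 1.4-fold lower number from compound 2 to compound 4 (0.13 log units; within the scatter). Compound 4 is expected at 2800 nM, within a range from 1400 nM to 5600 nM.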

Compound 4, half-maximal inhibitory concentration: 1990 nM
Compound 4: middle estimate off by 1.4-fold (0.15 log units), on the high side; measured number inside the range.
By their numbers in this assay, from the lowest: compounds 1, 4, 3 and 2 (each within the scatter of the next, the first and the last beyond it).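

With a 1.9-fold lower number from compound 2 to compound 4 (0.28 log units; within the scatter), methoxy joins hydroxy as a replacement for hydrogen whose step stays within the scatter, so a group larger than a single atom has not yet moved the number clearly. All three replacements on the shared core point the same way, with none going against it, but only bromo in compound 1 stands beyond the scatter from compound 2. Nothing shown here explains the size or direction of these steps. As far as these compounds go, whether an amine, a carboxylic acid or a longer chain such as butoxy would give a clear step on this ring remains open.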